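Methyl on a Saturated Ring Carbon of a Shared Amide Series

A few compounds are considered here, and "the series" means these few. Any claim that something is new, unique, unknown or untested is made for them only; others in the source may bear on it.

Measured compounds:
- compound 1, `Cc1nc(Nc2ccc3sc(C(=O)Nc4c(C)cccc4Cl)cc3c2)cc(N2CCCCC2)n1`: "not determined" (no result reported) in a functional assay on K562 cells (Homo sapiens) for cytotoxicity, read by MTT assay and WST assay, with a stated time of 72 h; a lower number here means a stronger inhibitor, a higher number a weaker inhibitor
- compound 2, `COc1cc2c(Nc3ccc4sc(C(=O)Nc5c(C)cccc5Cl)cc4c3)ncnc2cc1OCCCN1CCCCC1C`: 2150 nM

The account concerns two compounds that share the amide portion of their structure but differ in their core. Compound 2 carries a different core from compound 1, and in this assay compound 2 gives 2150 nM. Going by the values given here, compound 1 stands without a number in this assay, so its position cannot be placed against compound 2, and no step between the two can be stated; only the result of compound 2 is known.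

The step under consideration leads from compound 1 to compound 3, `Cc1nc(Nc2ccc3sc(C(=O)Nc4c(C)cccc4Cl)cc3c2)cc(N2CCC(C)CC2)n1`. The change is methyl in place of hydrogen on a saturated ring carbon. Among the compounds with values here, since no measured pair shows what such a change does in this assay, the expected step is small, with no direction that could be claimed beyond the scatter. Compound 3 is therefore expected to give about 2000 nM in this assay, with a range from 500 nM to 8000 nM.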

Compound 3, half-maximal inhibitory concentration: 22200 nM
For compound 3 the middle estimate is 11-fold (1.05 log units) below the measured one, and the stated range ends below it.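

Compound 1 has no single number to set against compound 3, and compound 2 differs from compound 3 in more than one place, so no step can be read from this result. The compounds shown leave open what piperidin-1-yl to 4-methylpiperidin-1-yl does to the result in this assay. No evidence bearing on the result is available.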